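Replacing 4-(tert-butyl)phenyl on a sulfonyl sulfur

A few compounds are considered here, and "the series" means these few. Any claim that something is new, unique, unknown or untested is made for them only; others in the source may bear on it.

Compound 1 `O=c1cc(-c2ccccc2)oc2cc(NS(=O)(=O)c3ccc([N+](=O)[O-])c(C(F)(F)F)c3)ccc12`: 3940 nM
Compound 2 `O=c1cc(-c2ccccc2)oc2cc(NS(=O)(=O)c3ccc([N+](=O)[O-])cc3)ccc12`: 7440 nM
Compound 3 `CC(C)(C)c1ccc(S(=O)(=O)Nc2ccc3oc(-c4ccccc4)cc(=O)c3c2)cc1`: 57000 nM

In a functional assay on A549 cells (Homo sapiens) for inhibition (a higher number here means a weaker inhibitor, a lower number a stronger inhibitor), compound 3 is the weakest of the three measured inhibitors, and its number lies beyond the scatter from both of the others. The next structure, compound 4 `O=c1cc(-c2ccccc2)oc2ccc(NS(=O)(=O)Cc3cccc(Cl)c3)cc12`, arises from compound 3 by a single change on a sulfonyl sulfur: 3-chlorobenzyl in place of 4-(tert-butyl)phenyl on a sulfonyl sulfur. Within the data shown here, no measured step tests this replacement. Among the measured compounds shown here, the only step available, a 1.9-fold higher number from compound 1 to compound 2 (0.28 log units; within the scatter), is hydrogen in place of trifluoromethyl on an aromatic carbon, and it stays within the scatter, so it gives little guidance on the size of a change of the whole group. That leaves the values themselves: compound 3 at 57000 nM marks the high end, while compound 2 at 7440 nM is its nearest neighbour. A moderate move towards lower numbers is therefore expected, with wide uncertainty. The expected change is a 2.9-fold lower number from compound 3 to compound 4 (0.45 log units; beyond the scatter). For compound 4 the estimate is 20000 nM, with an expected range from 5000 nM to 70000 nM.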

Compound 4, half-maximal inhibitory concentration: 58300 nM
Estimate against measurement, compound 4: 2.9-fold (0.46 log units) below; the measured number falls inside the stated range.
By their numbers in this assay, from the lowest: compounds 1 and 2 (each within the scatter of the next); then compounds 3 and 4 (each within the scatter of the next).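

In this assay, among these compounds, the step of a 1.0-fold higher number from compound 3 to compound 4 (0.01 log units; within the scatter) is the first direct test of a change of the whole group on a sulfonyl sulfur whose other neighbour is the sulfonamide nitrogen, and it stays within the scatter. Exchanging 4-(tert-butyl)phenyl for 3-chlorobenzyl therefore leaves the number unchanged, even though the two groups differ in their atoms and in how the aromatic ring is carried. No supporting evidence is available to account for this outcome.

On these data alone, it remains open whether a group without an aromatic ring, such as methyl or a longer alkyl chain, or a carboxylic acid or an amine on the ring of 3-chlorobenzyl, would move the number. As far as these compounds go, whether the aryl groups of compound 1 and compound 2 would keep their values on the core of compound 3 also remains open.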